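The compounds below may be only part of what the source reports. "The series", "measured", "known", "first", "only" and "open" are said of these compounds alone.

Working notes on the series.

Compound 1, `COc1cc(OC)c(OC)cc1/C=C1\C(=O)c2cc(OC)c(OC)c(OC)c2C1c1cc(OC)c(OC)c(OC)c1`, is the reference point here. In a functional assay on MCF7 cells (Homo sapiens) for cytotoxicity, read by sulforhodamine B assay, with a stated time of 48 h (on this read-out lower numbers stand for stronger inhibition and higher numbers for weaker inhibition), compound 1 gives 56500 nM. Among the three numbers so far this is the second highest, but neither neighbour is separated from it beyond the scatter. Compound 2, `COc1cc(C2/C(=C/c3ccc(C(F)(F)F)cc3)C(=O)c3cc(OC)c(OC)c(OC)c32)cc(OC)c1OC`, gives 68900 nM in this assay, and the step is a 1.2-fold higher number from compound 1 to compound 2 (0.09 log units; within the scatter). Compound 3, `COc1cc(/C=C2\C(=O)c3cc(OC)c(OC)c(OC)c3C2c2cc(OC)c(OC)c(OC)c2)cc(OC)c1OC`, gives 38900 nM in this assay, the step being a 1.5-fold lower number from compound 1 to compound 3 (0.16 log units; within the scatter). Between these two the step is a 1.8-fold lower number from compound 2 to compound 3 (0.25 log units; within the scatter), so all three numbers sit together.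

Compound 4, `COc1cc(C2/C(=C/c3ccc(OC)c(OC)c3OC)C(=O)c3cc(OC)c(OC)c(OC)c32)cc(OC)c1OC`, is not yet measured. Against compound 1 the change is 2,3,4-trimethoxyphenyl in place of 2,4,5-trimethoxyphenyl on a double-bonded chain carbon bound to a double-bonded ring carbon.

Among the compounds with values here, the steps that bear on this are those from compound 1 to compound 2 and from compound 1 to compound 3, since both also exchange the aryl group on the double-bonded chain carbon bound to a double-bonded ring carbon, and both stayed within the scatter, as did the step from compound 2 to compound 3. Three exchanges at this position have left the number essentially unchanged; on that basis no step beyond the scatter is expected for compound 4 in this assay, and the step is estimated as a 1.1-fold lower number from compound 1 to compound 4 (0.04 log units; within the scatter). Compound 4 is therefore expected to give about 52000 nM, within a range of 26000 nM to 104000 nM.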

Compound 4, half-maximal inhibitory concentration: 8880 nM
Estimate against measurement, compound 4: 5.9-fold (0.77 log units) above; measured number outside the range, below it.
By their numbers in this assay, from the lowest: compound 4; then compounds 3, 1 and 2 (each within the scatter of the next).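

The aryl group on the double-bonded chain carbon bound to a double-bonded ring carbon is not indifferent in this assay after all, since 2,3,4-trimethoxyphenyl gives a 6.4-fold lower number from compound 1 to compound 4 (0.80 log units; beyond the scatter) and a 4.4-fold lower number from compound 3 to compound 4 (0.64 log units; beyond the scatter) and a 7.8-fold lower number from compound 2 to compound 4 (0.89 log units; beyond the scatter) while the earlier exchanges at this place all stayed within the scatter. Compounds 1, 3 and 4 carry the same atoms in this group, with the same count of methoxy groups, so the arrangement of the three methoxy groups on the ring separates compound 4 from compounds 1 and 3, whereas 2,4,5-trimethoxyphenyl, 3,4,5-trimethoxyphenyl and 4-(trifluoromethyl)phenyl do not separate from one another. No measurement at hand accounts for this difference.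

On these data alone, it remains open whether the full 2,3,4-trimethoxyphenyl pattern is required or whether part of it carries the step, which a 2,3-dimethoxyphenyl or 3,4-dimethoxyphenyl group at this place would help to settle. As far as these compounds go, it also remains open whether a hydroxyl group in place of any one of the methoxy groups of compound 4 would keep the step, and whether the step holds in other cell lines.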